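Adding a Second Chloro to the Benzyl Ether of Compound 3

The source may hold more compounds than are shown below. What is called first, only, known or untested is meant among the compounds shown, and "the series" means these compounds.

Measured compounds in a functional assay on A549 cells (Homo sapiens) for antiproliferative activity, read by MTT assay, with a stated time of 48 h, in the presence of a further agent that is not named here; a higher number here means a weaker inhibitor of growth, a lower number a stronger inhibitor of growth:
- compound 1, `O=C(NOCc1ccc(Cl)cc1Cl)c1cn(-c2ccccc2)nc1-c1ccccc1`, gives 7350 nM
- compound 2, `Cc1ccc(-c2nn(-c3ccccc3)cc2C(=O)NOCc2ccc(Cl)cc2Cl)cc1`, gives 1080 nM
- compound 3, `O=C(NOCc1ccccc1Cl)c1cn(-c2ccccc2)nc1-c1ccc(Cl)cc1`, gives 15500 nM

Compound 3 stands highest of the three numbers in this assay; compound 1 sits nearest, and compound 2 lies furthest from it. Compound 4, `O=C(NOCc1ccc(Cl)cc1Cl)c1cn(-c2ccccc2)nc1-c1ccc(Cl)cc1`, differs from compound 3 by chloro in place of hydrogen on an aromatic carbon. Within the data shown here, no measured step places a chloro on the benzyl ether, so none bears on this change directly. Among the measured compounds shown here, the only single-place step known, a 6.8-fold lower number from compound 1 to compound 2 (0.83 log units; beyond the scatter), concerns the other ring and gives a modest shift. For the measured compounds named here, compound 1 and compound 3 differ in two places at once, so their values show only that the two dichlorobenzyl compounds sit lower than compound 3. From this, the step for compound 4 is expected to be small to modest and downward, a 3.1-fold lower number from compound 3 to compound 4 (0.49 log units; beyond the scatter), with wide uncertainty. Compound 4 is therefore estimated at 5000 nM, within a range from 1500 nM to 15000 nM.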

Compound 4, concentration for 50% growth inhibition: 13100 nM
Compound 4: middle estimate off by 2.6-fold (0.42 log units), on the low side, within the range that was stated.
By their numbers in this assay, from the lowest: compound 2; then compounds 1, 4 and 3 (each within the scatter of the next, the first and the last beyond it).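

In this assay, going from 2-chlorobenzyl to 2,4-dichlorobenzyl gives a 1.2-fold lower number from compound 3 to compound 4 (0.07 log units; within the scatter), so with chloro on the other aromatic ring, this second chloro on the benzyl ether leaves the number within the scatter. That other ring now reads more clearly: chloro in place of hydrogen gives a 1.8-fold higher number from compound 1 to compound 4 (0.25 log units; within the scatter), whereas chloro in place of methyl gives a 12-fold higher number from compound 2 to compound 4 (1.08 log units; beyond the scatter), which sets methyl apart from both hydrogen and chloro among these compounds. No measurement shown here accounts for these steps.

On these data alone, it remains open whether the second chloro on the benzyl ether would also leave the number within the scatter with methyl or hydrogen on the other ring. Also open, as far as these compounds go, is whether a methoxy group or an amine at that place would track methyl or chloro.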